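Adding a second methoxy group to a covalent HeLa inhibitor

A few compounds are considered here, and "the series" means these few. Any claim that something is new, unique, unknown or untested is made for them only; others in the source may bear on it.

Measured compounds:
compound 1 `Nc1cccc(-c2cn3nc(Cc4ccccc4)sc3n2)c1`, 24000 nM
compound 2 `COc1ccc(Cc2nn3cc(-c4cccc(N)c4)nc3s2)cc1`, 191000 nM
compound 3 `C=C(Br)C(=O)Nc1cccc(-c2cn3nc(-c4cccc(OC)c4)sc3n2)c1`, 1100 nM

Of the compounds shown here, three have been tested in a functional assay on HeLa cells (Homo sapiens) for inhibition, read by cell counting, with a stated time of 4 days; on this read-out higher numbers stand for weaker inhibition and lower numbers for stronger inhibition. Compound 2 differs from compound 1 by methoxy in place of hydrogen on an aromatic carbon, and this change gave an 8.0-fold higher number from compound 1 to compound 2 (0.90 log units; beyond the scatter). Compound 3 carries a different core; the difference between its core and that of compound 1 is not broken down here. In this assay compound 3 gives the lowest number of the three.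

Compound 4 `C=C(Br)C(=O)Nc1cccc(-c2cn3nc(-c4ccc(OC)c(OC)c4)sc3n2)c1` is not yet measured. It differs from compound 3 by methoxy in place of hydrogen on an aromatic carbon. This is the same kind of change as that from compound 1 to compound 2, but not the same: in compound 4 the new group sits ortho to a methoxy group, which is not so in compound 2. Because the earlier change gave an 8.0-fold higher number from compound 1 to compound 2 (0.90 log units; beyond the scatter), a weaker inhibition is expected here too, though the different surroundings and the different core leave the size uncertain, so a smaller step, a 3.2-fold higher number from compound 3 to compound 4 (0.50 log units; beyond the scatter), is estimated. Compound 4 is therefore expected to give about 3500 nM, most likely between 1000 nM and 12000 nM.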

Compound 4, half-maximal inhibitory concentration: 610 nM
The estimate for compound 4 lay 5.7-fold (0.76 log units) above the measured number; measured number outside the range, below it.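

In this assay, methoxy in place of hydrogen gave a 1.8-fold lower number from compound 3 to compound 4 (0.26 log units; within the scatter), so the added group leaves the two compounds indistinguishable on this core. Set beside the earlier step, the change does not carry over from one core to the other with the same result: the same change on two cores in this assay, an 8.0-fold higher number (0.90 log units; beyond the scatter) from compound 1 to compound 2 and a 1.8-fold lower number (0.26 log units; within the scatter) from compound 3 to compound 4, 14-fold (1.16 log units) apart, beyond the scatter of two such steps

This does not show what sets the two steps apart, since the pairs differ in more than the core: in compound 4 the new methoxy sits ortho to a methoxy group, which is not so in compound 2, and two pairs cannot separate these differences or predict the change on any further core.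

On these data alone, it remains open what another group would do in the same place on compound 3, such as a hydroxyl, an ethoxy or an amine. Also open, as far as these compounds go, is how the 3,4-dimethoxyphenyl group would behave on the core of compound 1, which would separate the role of the core from that of the neighbouring methoxy.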